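Side-chain change from compound 2 to compound 4

The source may report more compounds than this note shows. Statements on the series, on what has been measured and on what is new or still open speak of the compounds shown alone.

In an ADME assay on MT4 cells (Homo sapiens) for cytotoxicity, read by MTT assay, with a stated time of 5 days (on this read-out lower numbers stand for higher toxicity in this test and higher numbers for lower toxicity in this test), compound 2 `Cc1cc(/C=C/C#N)cc(C)c1Oc1cc(NCCN(C)C)nc(Nc2ccc(C#N)cc2)c1` gives 4270 nM. Compound 1 `Cc1cc(/C=C/C#N)cc(C)c1Oc1cc(NCCN(C)C)nc(Nc2ccc(C#N)cc2)n1` gives 3040 nM, and these two values lie within the scatter of each other. Compound 3 `Cc1cc(/C=C/C#N)cc(C)c1Oc1cc(NCCC#N)nc(Nc2ccc(C#N)cc2)n1` gives 1000 nM, the lowest of the three numbers and clearly apart from the other two.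

Compound 4 `Cc1cc(/C=C/C#N)cc(C)c1Oc1cc(NCCN2CCN(C)CC2)nc(Nc2ccc(C#N)cc2)c1` keeps the core of compound 2 and differs only at the end of the chain: 4-methylpiperazin-1-yl in place of dimethylamino on a saturated chain carbon, two bonds along the chain from a nitrogen on an aromatic ring. In words, this is 4-methylpiperazin-1-yl in place of dimethylamino on a saturated chain carbon, two bonds along the chain from a nitrogen on an aromatic ring.

Among the measured compounds shown here, the only measured step at this place is a 3.0-fold lower number from compound 1 to compound 3 (0.48 log units; beyond the scatter), with cyano entering in place of dimethylamino. For the measured compounds named here, that step is modest and brings in a different group, so it shows only that the number can move when this group changes. Going by the values given here, no measured step has a ring entering here, and the direction is poorly supported. A small shift towards a lower number is the most that can be expected. The step expected is a 1.2-fold lower number from compound 2 to compound 4 (0.09 log units; within the scatter), an estimate that stays within the scatter. For compound 4 the estimated value is 3500 nM, with an expected range of 1500 nM to 8000 nM.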

Compound 4, half-maximal cytotoxic concentration: 7960 nM
Estimate against measurement, compound 4: 2.3-fold (0.36 log units) below, within the range that was stated.
By their numbers in this assay, from the lowest: compound 3; then compounds 1, 2 and 4 (each within the scatter of the next, the first and the last beyond it).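

Working notes on the chain end: in this assay, the step of a 1.9-fold higher number from compound 2 to compound 4 (0.27 log units; within the scatter) lies within the usual scatter, whereas the cyano step a 3.0-fold lower number from compound 1 to compound 3 (0.48 log units; beyond the scatter) on the other core lies beyond it. On the core of compound 2, therefore, the chain end accepts 4-methylpiperazin-1-yl, the only group shown here with a six-membered non-aromatic ring, in place of dimethylamino without a change that can be told from scatter, even though the heavy atoms of the group rise from 3 to 7. This single pair cannot show a trend with group size, and no measurement on hand accounts for the result.

Still open is whether 4-methylpiperazin-1-yl behaves the same way on the core of compound 1, where the dimethylamino and cyano chain ends are the pair shown, and whether the cyano end would give a similar step on the core of compound 2. Also open, on these data alone, is how this read-out responds to other chain ends at this place, such as morpholin-4-yl, a hydroxyl group, a carboxylic acid or a longer chain between the ring nitrogen and the terminal amine.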